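Swapping Cyano for Nitro in Compound 2

This account rests on a few compounds, and the source may have more. Where it says the series, first, only, none or still open, it means among the compounds named here.

Compound 1 `CC(O)(CS(=O)(=O)c1cccc(S(F)(F)(F)(F)F)c1)C(=O)Nc1cccc(S(F)(F)(F)(F)F)c1` gives 15400 nM
Compound 2 `CC1(C)C(=O)N(c2ccc(C#N)cc2C(F)(F)F)C(=S)N1c1ccc(S(F)(F)(F)(F)F)cc1` gives 5400 nM

In a functional assay on CWR22R cells (Homo sapiens) for antiproliferative activity, read by propidium iodide staining, with a stated time of 96 h (on this read-out higher numbers stand for weaker inhibition and lower numbers for stronger inhibition), compound 2 has the lower of the two numbers, at 5400 nM and so the stronger inhibition. The gap to compound 1 at 15400 nM lies beyond the usual scatter. Compound 3 `CC1(C)C(=O)N(c2ccc([N+](=O)[O-])cc2C(F)(F)F)C(=S)N1c1ccc(S(F)(F)(F)(F)F)cc1` differs from compound 2 in one place, with nitro in place of cyano on an aromatic carbon and the rest unchanged. Going by the values given here, no measured pair shows this swap, so the estimate is uncertain. The expected step of a 1.1-fold lower number from compound 2 to compound 3 (0.03 log units; within the scatter) stays within the scatter in this assay and has no clear direction. For compound 3 the estimated value is 5000 nM (expected range 2000 nM to 13000 nM).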

Compound 3, half-maximal inhibitory concentration: 100000 nM
Compound 3: middle estimate off by 20-fold (1.30 log units), on the low side; the whole stated range lies below it.
By their numbers in this assay, from the lowest: compound 2; then compound 1; then compound 3.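

In this assay the position para to a large group proves sensitive to what sits on it, since nitro in place of cyano weakens inhibition sharply (a 19-fold higher number from compound 2 to compound 3 (1.27 log units; beyond the scatter)). Cyano and nitro are therefore not interchangeable here, a point the earlier compounds could not show. Nothing available explains this loss. From the compounds shown here alone, whether an amine or a carboxylic acid at this position would restore or further weaken inhibition remains open. A single swap also leaves open how far other groups here would shift the number.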